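Swapping a chloro for a trifluoromethyl on the aryl ring

The compounds below may be only part of what the source reports. "The series", "measured", "known", "first", "only" and "open" are said of these compounds alone.

Of the compounds shown here, three sharing one core have been tested in a functional assay on the whole organism for inhibition, with Mus musculus as the target, with a stated time of 0.5 h; a higher number here means that more compound is needed for the effect, a lower number that less compound is needed. Compound 1, `CC1(C)CC12NC(=O)N(NC(=O)c1ccccc1)C2=O`, gives 300 mg/kg. Compound 2, `CC1(C)CC12NC(=O)N(NC(=O)c1ccc(Cl)cc1)C2=O`, gives 300 mg/kg. Compound 3, `CC1(C)CC12NC(=O)N(NC(=O)c1ccccc1Cl)C2=O`, gives 300 mg/kg. Compound 2 therefore stands level with compound 1 and compound 3 in this assay.

The next compound, compound 4, `CC1(C)CC12NC(=O)N(NC(=O)c1ccc(C(F)(F)F)cc1)C2=O`, differs from compound 2 by trifluoromethyl in place of chloro on an aromatic carbon.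

The measured steps that bear on this change all sit on the same aromatic ring. Chloro in place of hydrogen gave no change at the digits printed from compound 1 to compound 2 (within the scatter) and no change at the digits printed from compound 1 to compound 3 (within the scatter), and moving the chloro gave no change at the digits printed from compound 2 to compound 3 (within the scatter). Every substitution tried on that ring so far left the dose unmoved, so a trifluoromethyl in the same position is expected to do the same: the step of no change at the digits printed from compound 2 to compound 4 (within the scatter) is estimated to lie within the scatter. Compound 4 is expected to need 300 mg/kg, with a range from 150 mg/kg to 600 mg/kg.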

Compound 4, minimum effective dose: 300 mg/kg
Compound 4: middle estimate and measured number agree at the digits printed; measured number inside the range.
By their numbers in this assay, from the lowest: compounds 1, 2, 3 and 4 (each within the scatter of the next).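

In this assay, the ring position para to a large group now carries trifluoromethyl, a group with more heavy atoms than chloro and one that is not a lone halogen atom, and the step shows no change at the digits printed from compound 2 to compound 4 (within the scatter) at this position. Measured against plain hydrogen, the same group gives no change at the digits printed from compound 1 to compound 4 (within the scatter), so hydrogen, chloro and trifluoromethyl all sit at one printed dose at this position. No measurement at hand explains why the dose stays level across these groups.

As far as these compounds go, whether an amine, a carboxylic acid or a longer alkyl chain at this position would shift the dose remains open. Also open, from the compounds shown here alone, is whether a change to the shared core, rather than to the aromatic ring, would move the dose at all.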